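Propyl on the Linking Nitrogen of Compound 1

A few compounds are considered here, and "the series" means these few. Any claim that something is new, unique, unknown or untested is made for them only; others in the source may bear on it.

Compound 1 `Nc1nc(N)c2nc(Nc3ccccc3)ccc2n1` is measured in an ADME assay on isolated protein for inhibition of Dihydrofolate reductase (Homo sapiens), using NADPH (a lower number here means a stronger inhibitor, a higher number a weaker inhibitor), where compound 1 gives 1530 nM, the lowest of the three numbers in hand. Compound 2 `Cc1ccc(Nc2ccc3nc(N)nc(N)c3n2)cc1` gives 2630 nM in this assay, and compound 3 `Nc1nc(N)c2nc(Nc3ccc(OC(F)(F)F)cc3)ccc2n1` gives 4130 nM. Both neighbours differ from compound 1 only on the outer aromatic ring: a 1.7-fold higher number from compound 1 to compound 2 (0.24 log units; within the scatter), whereas a 2.7-fold higher number from compound 1 to compound 3 (0.43 log units; beyond the scatter). Compound 4 `CCCN(c1ccccc1)c1ccc2nc(N)nc(N)c2n1` alters compound 1 at a different place: propyl in place of hydrogen on a nitrogen on an aromatic ring. For the measured compounds named here, no measured step touches this nitrogen, so the two steps on the outer ring are the only guides, and they show that each addition to compound 1 so far has given a number within the scatter or modestly higher. Going by the values given here, the change to compound 4 lies at a place none of the measured steps tests, so the expectation carries wide uncertainty, but a modest loss rather than a gain is the expected direction. Compound 4 is therefore estimated at 3200 nM, with a range from 1000 nM to 10000 nM, which is expected to mean a 2.1-fold higher number from compound 1 to compound 4 (0.32 log units; beyond the scatter).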

Compound 4, half-maximal inhibitory concentration: 1340 nM
For compound 4 the middle estimate is 2.4-fold (0.38 log units) above the measured one, within the range that was stated.
By their numbers in this assay, from the lowest: compounds 4, 1, 2 and 3 (each within the scatter of the next, the first and the last beyond it).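

Placing propyl on the linking nitrogen gives a 1.1-fold lower number from compound 1 to compound 4 (0.06 log units; within the scatter) in this assay, so this nitrogen, a place no earlier step had tested, takes the added chain with no difference that stands out from the scatter. The hydrogen on this nitrogen can therefore be replaced here without the loss seen on the outer ring, where trifluoromethoxy gives a 2.7-fold higher number from compound 1 to compound 3 (0.43 log units; beyond the scatter) in the same assay. No measurement in hand explains this result.

From the compounds shown here alone, it remains open whether a longer chain, a chain ending in an amine or one ending in a carboxylic acid would fit on this nitrogen as propyl does. Going by these compounds, it is also open whether propyl here would leave the number unchanged when the outer ring carries methyl or trifluoromethoxy.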